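Adding methyl to the cyclopentenyl ring of compound 2

A few compounds are considered here, and "the series" means these few. Any claim that something is new, unique, unknown or untested is made for them only; others in the source may bear on it.

Values so far in a functional assay on MT2 cells (Homo sapiens) for cytotoxicity, read by MTT assay; a lower number here means that less compound is tolerated, a higher number that more compound is tolerated
- compound 1 `Clc1ccc(Nc2nccs2)cc1OCc1ccsc1` gives 38000 nM
- compound 2 `Clc1ccc(Nc2nccs2)cc1OCC1=CCCC1` gives 15000 nM

Compound 2 holds the lower of the two numbers. Compound 3 `CC1=C(COc2cc(Nc3nccs3)ccc2Cl)CCC1` has methyl in place of hydrogen on a double-bonded ring carbon, next to the ring atom that bears a large group (methyl in place of hydrogen on a double-bonded ring carbon). Among the measured compounds shown here, the only measured step, a 2.5-fold lower number from compound 1 to compound 2 (0.40 log units; beyond the scatter) for cyclopent-1-en-1-yl in place of thiophen-3-yl, is modest. For the measured compounds named here, it exchanges a whole ring, so it is only a loose guide, and no measured step isolates a methyl. In this assay a small shift toward a lower number is expected, probably not beyond the scatter. The expected change is a 1.3-fold lower number from compound 2 to compound 3 (0.10 log units; within the scatter) on this estimate. Compound 3 is expected at 12000 nM with an estimated range from 5500 nM to 26000 nM in this series.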

Compound 3, half-maximal cytotoxic concentration: 11000 nM
Compound 3: the middle estimate sits 1.1-fold (0.04 log units) above what was measured, within the range that was stated.
By their numbers in this assay, from the lowest: compounds 3 and 2 (each within the scatter of the next); then compound 1.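

In this assay, methyl in place of hydrogen on a double-bonded ring carbon gives a 1.4-fold lower number from compound 2 to compound 3 (0.13 log units; within the scatter) and so, at this position next to the ring atom that bears a large group, the added methyl produces no shift that can be told from the scatter. With the methyl present, the exchange of the thiophen-3-yl group for 2-methylcyclopent-1-en-1-yl gives a 3.5-fold lower number from compound 1 to compound 3 (0.54 log units; beyond the scatter) and remains beyond the scatter, so the gap to compound 1 seen with compound 2 persists in compound 3. Nothing available here offers an explanation for either step.

A single methyl on a single ring carbon leaves open whether a longer chain such as ethyl, or a hydroxymethyl or a carboxylic acid, at this ring carbon would move the number beyond the scatter. Whether the ring double bond matters also stays open, as a saturated cyclopentyl ring is not among the compounds shown.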